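Replacing the propargyl chain of compound 3 with a fluorophenacyl chain

The source may report more compounds than this note shows. Statements on the series, on what has been measured and on what is new or still open speak of the compounds shown alone.

Measured in a functional assay on A549 cells (Homo sapiens) for cytotoxicity, read by MTT assay, with a stated time of 48 h; on this read-out lower numbers stand for stronger inhibition and higher numbers for weaker inhibition:
compound 1 `CCc1nnc(SCC(=O)c2ccc(Cl)cc2)n1N1C(=O)c2ccccc2C1=O`, > 200000 nM;
compound 2 `CCCc1nnc(SCc2ccccc2)n1N1C(=O)c2ccccc2C1=O`, > 200000 nM;
compound 3 `C#CCSc1nnc(-c2cc(OC)c(OC)c(OC)c2)n1N1C(=O)c2ccccc2C1=O`, > 200000 nM.

Each of these values is a limit of the assay, not a number. For the measured compounds named here, compound 3 therefore stands nowhere in particular: the limit of > 200000 nM in this assay, at which 3 of the 3 values shown sit, and no compound is separated from another. Compound 4 `COc1cc(-c2nnc(SCC(=O)c3ccc(F)cc3)n2N2C(=O)c3ccccc3C2=O)cc(OC)c1OC` differs from compound 3 by (4-fluorophenyl)carbonyl in place of ethynyl on a saturated chain carbon bound to a sulfur. Going by the values given here, no step between measured compounds is known, so nothing shows how this change acts. Compound 1 carries a chain of similar kind and gives a limit of > 200000 nM. Compound 4 is expected to sit at the limit again, a step that the limit leaves unreadable from compound 3 to compound 4, none beyond the scatter. Compound 4 is estimated at 250000 nM, between 60000 nM and 1000000 nM.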

Compound 4, half-maximal inhibitory concentration: > 200000 nM
Compound 4: no number, only a limit; the forecaster's own chance of this, stated with the estimate: 80%; the middle value does not contradict the limit.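

No step can be read from compound 3 to compound 4, because both values are limits and not numbers: the limit of > 200000 nM in this assay, at which 4 of the 4 values shown sit.

Whether swapping the propargyl chain for the ((4-fluorophenyl)carbonyl)methyl chain changes activity at all stays open, and no compound shown gives a number to compare.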